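This account rests on a few compounds, and the source may have more. Where it says the series, first, only, none or still open, it means among the compounds named here.

Working notes on the series. In an assay on Jurkat cells for activation of nuclear factor NF-kappa-B complex (Homo sapiens) (a lower number here means a stronger inhibitor, a higher number a weaker inhibitor), compound 1 `CCc1nc(Cl)ncc1C(=O)Nc1cc(C(F)(F)F)cc(C(F)(F)F)c1` gives 400 nM. Compound 2 `O=C(Nc1cc(C(F)(F)F)cc(C(F)(F)F)c1)c1ccc(Cl)nn1` gives 1700 nM in this assay; of the two numbers in hand, compound 1 has the lower one, and its gap to compound 2 is beyond the scatter of repeated measurements. For compound 3 `Cc1ncc(C(=O)Nc2cc(C(F)(F)F)cc(C(F)(F)F)c2)c(C(F)(F)F)n1` this assay reports only a limit, > 10000 nM; > 10000 nM (2 entries), in both of two entries. Within the data shown here, compound 3 differs from compound 1 in more than one place, so it sets no single step.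

Compound 4 `O=C(Nc1cc(C(F)(F)F)cc(C(F)(F)F)c1)c1cnc(Cl)nc1C(F)(F)C(F)(F)F` is not yet measured in this assay. It differs from compound 1 in one place:
1,1,2,2,2-pentafluoroethyl in place of ethyl on an aromatic carbon
Among the measured compounds shown here, no measured pair shows this change, so the size of its step is open. The expected step is a 2.0-fold higher number from compound 1 to compound 4 (0.30 log units; within the scatter), a modest move toward a higher number, of a size near the edge of the scatter. Compound 4 is estimated at 800 nM in this assay, with a range from 250 nM to 3000 nM.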

Compound 4, half-maximal inhibitory concentration: 800 nM
Compound 4: the middle estimate sits on the measured number at the digits printed, and the stated range covers the measured number.
By their numbers in this assay, from the lowest: compounds 1 and 4 (each within the scatter of the next); then compound 2.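

Among these compounds, exchanging ethyl for 1,1,2,2,2-pentafluoroethyl on the aromatic carbon next to the ring nitrogen gives a 2.0-fold higher number from compound 1 to compound 4 (0.30 log units; within the scatter) in this assay as the first reading of any change at this position. Within the scatter, this assay does not separate the two groups, so this carbon accepts a chain that is fully fluorinated and larger by heavy-atom count without a measurable change in the number. No measurement in hand bears on the reason for this result.

From the compounds shown here alone, with one step at this carbon, it remains open how a methyl group, a cyclopropyl ring, an amine or a longer chain such as butyl would read here. Also open, going by these compounds, is whether the same exchange gives a similar step when an amine replaces the chloro group on the core of compound 1.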